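The source may hold more compounds than are shown below. What is called first, only, known or untested is meant among the compounds shown, and "the series" means these compounds.

Compound 1, `COc1ccc(-c2cnc3nc(N)nc(N4CCN(C(=O)NCc5ccc(F)cc5)CC4)c3n2)cc1OC`, in a functional assay on cells (T-cell, Homo sapiens) for inhibition (a lower number here means a stronger inhibitor, a higher number a weaker inhibitor), gives 37 nM.
Compound 2, `COc1ccc(-c2cnc3nc(N)nc(NC(C)C)c3n2)cc1OC`, in this assay gives 600 nM.
Compound 3, `CC(C)Oc1nc(N)nc2ncc(-c3ccc(C(F)(F)F)cc3)nc12`, in this assay reaches only a limit of the assay, > 10000 nM, (the limit of > 10000 nM in this assay, at which 1 of the 3 values shown sits).

Among the two numbers shown, compound 1 holds the lower one; the gap to compound 2 lies beyond the scatter. Compound 4, `COc1ccc(-c2cnc3nc(N)nc(N4CCN(c5ccccc5)CC4)c3n2)cc1OC`, is not yet measured. It differs from compound 1 by phenyl in place of (4-fluorobenzyl)carbamoyl on an amine nitrogen in a ring. For the measured compounds named here, no measured pair shows this change, so its size is a matter of expectation only. The carbamoyl part with its donor and acceptor leaves, and a bare aromatic ring enters on the amine nitrogen in the ring. The expected step of a 4.1-fold higher number from compound 1 to compound 4 (0.61 log units; beyond the scatter) is a moderate loss, beyond the scatter, toward weaker inhibition. Compound 4 is therefore estimated at 150 nM, with a range from 40 nM to 600 nM.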

Compound 4, half-maximal inhibitory concentration: 400 nM
For compound 4 the middle estimate is 2.7-fold (0.43 log units) below the measured one; measured number inside the range.
By their numbers in this assay, from the lowest: compound 1; then compounds 4 and 2 (each within the scatter of the next). At a limit, above all of these: compound 3.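

The first step measured at this place, phenyl in place of (4-fluorobenzyl)carbamoyl on the amine nitrogen in the ring, is an 11-fold higher number from compound 1 to compound 4 (1.03 log units; beyond the scatter) and counts as large. The group on this nitrogen therefore strongly sets the number in this assay, and a phenyl ring there does not match the carbamoyl group of compound 1. Nothing measured here accounts for the size of this step.

Which part of the leaving group matters, the carbonyl, the amide hydrogen or the fluorinated ring, remains open. A benzyl or an acetyl group on the same nitrogen would begin to separate these parts.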